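From oxan-3-yl to 1H-pyrrol-3-yl on compound 1

This account rests on a few compounds, and the source may have more. Where it says the series, first, only, none or still open, it means among the compounds named here.

For the measured compounds named here, compound 1 `O=C(Nc1ccc(C(F)(F)F)cc1)NC1CCN(C(=O)C2CCCOC2)CC1` gives 1.1 ug/mL in a physicochemical assay for solubility, read by mass spectrometry, in phosphate buffer, with a stated time of 24 h, at pH 7.4 (a lower number here means a less soluble compound, a higher number a more soluble compound), and stands second highest of the three compounds measured so far. Compound 2 `O=C(Nc1ccc(C(F)(F)F)c(F)c1)NC1CCN(C(=O)C2CC2)CC1` gives a lower number at 0.46 ug/mL and compound 3 `O=C(Nc1ccc(OC(F)(F)F)c(F)c1)NC1CCN(C(=O)C2CCCOC2)CC1` a far higher one at 174 ug/mL in the same test. Compound 4 `O=C(Nc1ccc(C(F)(F)F)cc1)NC1CCN(C(=O)c2cc[nH]c2)CC1` has not yet been measured. Going by the values given here, it keeps the core of compound 1 and carries 1H-pyrrol-3-yl in place of oxan-3-yl on a carbonyl carbon as its only change. Among the compounds with values here, no two measured compounds differ in just one place, so the data hold no direct precedent for this swap, and the wide spread among the three values cannot be assigned to any single group. The expectation therefore starts from compound 1 at 1.1 ug/mL and stays close to it. The estimated 1.4-fold lower number from compound 1 to compound 4 (0.14 log units; within the scatter) is a small step downward in this assay and is not expected to lie beyond the scatter. Compound 4 is expected at 0.8 ug/mL with an estimated range from 0.15 ug/mL to 6 ug/mL when it is tested.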

Compound 4, solubility: 1.8 ug/mL
Estimate against measurement, compound 4: 2.3-fold (0.35 log units) below; low and high end bracket the measured number.
By their numbers in this assay, from the lowest: compound 2; then compounds 1 and 4 (each within the scatter of the next); then compound 3.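

For the compounds shown here, the pair of compound 1 and compound 4 is the first to differ in one place, and it gives a direct reading of this position in this assay. Placing 1H-pyrrol-3-yl in place of oxan-3-yl on a carbonyl carbon gives a 1.6-fold higher number from compound 1 to compound 4 (0.21 log units; within the scatter), so exchanging a six-membered non-aromatic ring for a five-membered aromatic ring with a hydrogen-bond donor leaves no readable difference here. No available evidence bears on this result.

The pair does not show whether an amine or a carboxylic acid on this carbonyl-linked ring would give a step beyond the scatter. It also leaves open whether the same swap would give a similar step with the trifluoromethoxy and fluorine substituents of compound 3 in place.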